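The source may report more compounds than this note shows. Statements on the series, on what has been measured and on what is new or still open speak of the compounds shown alone.

Compound 3, `COc1cc(-c2cc(/C=C/C(=O)c3ccc(Cl)c(Cl)c3)[nH]n2)cc(OC)c1OC`, belongs to a small series that shares one core and varies the group attached to the carbonyl carbon. In a functional assay on MCF7 cells (Homo sapiens) for inhibition, read by MTT assay, with a stated time of 48 h (on this read-out higher numbers stand for weaker inhibition and lower numbers for stronger inhibition), compound 3 gives 3200 nM. Its number sits between those of its two neighbours: compound 1, `COc1cc(-c2cc(/C=C3\Cc4ccccc4C3=O)[nH]n2)cc(OC)c1OC`, gives 4800 nM in this assay, and compound 2, `COc1cc(-c2cc(/C=C/C(=O)c3ccc(N)cc3)[nH]n2)cc(OC)c1OC`, gives 1600 nM, and both of these lie within the usual scatter of the number for compound 3, so no ordering among the three can be claimed.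

The next compound, compound 4, `COc1cc(-c2cc(/C=C/C(=O)c3ccccc3)[nH]n2)cc(OC)c1OC`, differs from compound 3 in one place: phenyl in place of 3,4-dichlorophenyl on a carbonyl carbon. Among the compounds with values here, one measured step bears on this change. Between compound 2 and compound 3 the aryl group on the carbonyl carbon was exchanged, 3,4-dichlorophenyl in place of 4-aminophenyl, and this gave a 2.0-fold higher number from compound 2 to compound 3 (0.30 log units; within the scatter). An exchange of one aryl group for another at the same carbonyl carbon thus left the read-out within the scatter, and the same outcome is expected when phenyl replaces 3,4-dichlorophenyl. For compound 4 the expected step is no change at the digits printed from compound 3 to compound 4 (within the scatter), with no clear direction. Compound 4 is therefore estimated at 3200 nM in this assay, with a range from 1300 nM to 8000 nM.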

Compound 4, half-maximal inhibitory concentration: 2100 nM
Beside the measured number, compound 4's estimate is 1.5-fold (0.18 log units) above it, within the range that was stated.
By their numbers in this assay, from the lowest: compounds 2, 4, 3 and 1 (each within the scatter of the next, the first and the last beyond it).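

In this assay, phenyl in place of 3,4-dichlorophenyl on the carbonyl carbon gave a 1.5-fold lower number from compound 3 to compound 4 (0.18 log units; within the scatter) and hydrogen in place of amino on an aromatic carbon gave a 1.3-fold higher number from compound 2 to compound 4 (0.12 log units; within the scatter). Compound 4 thus supplies the unsubstituted phenyl as a common reference, so the two chlorines and the amino group can each be read against it, and neither takes the read-out beyond the scatter in these three compounds. No independent measurement is available to account for this outcome.

The compounds shown leave open whether other groups on this phenyl, such as a carboxylic acid, a nitrile or a longer alkyl chain, would give a step beyond the scatter. They also leave open what would follow if a non-aromatic group, such as a cyclohexyl or a simple methyl, stood in place of the aryl group on the carbonyl carbon.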